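Exchanging the 4-methylphenyl group of compound 3

A few compounds are considered here, and "the series" means these few. Any claim that something is new, unique, unknown or untested is made for them only; others in the source may bear on it.

Compound 1 `Cc1cccc(NC(=O)Nc2cccc(CNc3nccnc3Cl)c2)c1` gives 9570 nM
Compound 2 `Cc1ccccc1NC(=O)Nc1cccc(CNc2nccnc2Cl)c1` gives 13600 nM
Compound 3 `Cc1ccc(NC(=O)Nc2cccc(CNc3nccnc3Cl)c2)cc1` gives 9820 nM

In a functional assay on T-24 cells (Homo sapiens) for antiproliferative activity, read by MTT assay, with a stated time of 48 h (on this read-out lower numbers stand for stronger inhibition and higher numbers for weaker inhibition), these three compounds cannot be told apart. Compound 3 stands level with the other two, since a 1.0-fold higher number from compound 1 to compound 3 (0.01 log units; within the scatter) and a 1.4-fold lower number from compound 2 to compound 3 (0.14 log units; within the scatter) both stay within the scatter.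

Going on to compound 4 `O=C(Nc1cccc(CNc2nccnc2Cl)c1)Nc1ccc(Cl)cc1Br` means 2-bromo-4-chlorophenyl in place of 4-methylphenyl on an amide-type nitrogen with 2-bromo-4-chlorophenyl in place of 4-methylphenyl on an amide-type nitrogen. The closest evidence is these two steps together with a 1.4-fold higher number from compound 1 to compound 2 (0.15 log units; within the scatter) and each of them only exchanges one methylphenyl group for another. None goes beyond the scatter. For the measured compounds named here, no measured compound carries bromine or chlorine on this group, so the effect of the new group remains untested, and any forecast must stay broad.

The expected change is a 1.2-fold lower number from compound 3 to compound 4 (0.09 log units; within the scatter) and it is not expected to be clearly beyond the scatter. Compound 4 is estimated at 8000 nM with an expected range from 2500 nM to 25000 nM in this estimate.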

Compound 4, half-maximal inhibitory concentration: 6650 nM
Beside the measured number, compound 4's estimate is 1.2-fold (0.08 log units) above it; the range from low to high includes it.
By their numbers in this assay, from the lowest: compounds 4, 1, 3 and 2 (each within the scatter of the next, the first and the last beyond it).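

For the compounds shown here, the 2-bromo-4-chlorophenyl group on this amide-type nitrogen gives the first step to pass the scatter in this assay, with a 2.0-fold lower number from compound 2 to compound 4 (0.31 log units; beyond the scatter), although that step is modest. The same exchange stays within the scatter against the other two methylphenyl compounds, with a 1.5-fold lower number from compound 3 to compound 4 (0.17 log units; within the scatter) and a 1.4-fold lower number from compound 1 to compound 4 (0.16 log units; within the scatter), so a larger group carrying bromine and chlorine is accepted here but clearly separates only from compound 2. No measurement shown here explains this difference.

The compounds shown leave open what bromine alone or chlorine alone on the phenyl ring would give, so the step cannot be divided between the two atoms. They also leave open how a carboxylic acid or an amine on that ring would compare.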